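The compounds below may be only part of what the source reports. "The series", "measured", "known", "first", "only" and "open" are said of these compounds alone.

Three compounds with a shared core, differing only in the group attached to the carbon that carries a double bond to nitrogen, have been measured in an assay on CHO-K1 cells for displacement of a labelled ligand from adenosine receptor A1 (Homo sapiens), read by scintillation counting, with a stated time of 60 min; a lower number here means a stronger inhibitor, a higher number a weaker inhibitor. Compound 1 `CC(=O)Nc1ccc(/C=N/Nc2nc(N)c3ncn([C@@H]4O[C@H](CO)[C@@H](O)[C@H]4O)c3n2)cc1` carries 4-acetamidophenyl there; in this assay compound 1 gives > 10000 nM, which is a limit of the assay rather than a number. Compound 2 `Nc1nc(N/N=C/c2ccc3ncccc3c2)nc2c1ncn2[C@@H]1O[C@H](CO)[C@@H](O)[C@H]1O` carries quinolin-6-yl and in this assay gives 9.8 nM. Compound 3 `CCCOc1ccc(/C=N/Nc2nc(N)c3ncn([C@@H]4O[C@H](CO)[C@@H](O)[C@H]4O)c3n2)cc1` carries 4-propoxyphenyl; in this assay compound 3 gives > 10000 nM, again a limit. Compound 3 therefore sits at the limit of > 10000 nM in this assay, at which 2 of the 3 values shown sit. The change from compound 2 to compound 3 was an at least 1000-fold higher number from compound 2 to compound 3 (3.00 log units; beyond the scatter), whereas the change from compound 1 to compound 3 was a step that the two limits leave unreadable from compound 1 to compound 3.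

Compound 4 `Nc1nc(N/N=C/C2CCCC2)nc2c1ncn2[C@@H]1O[C@H](CO)[C@@H](O)[C@H]1O` is the next step: cyclopentyl in place of 4-propoxyphenyl on a carbon with a double bond to nitrogen. Within the data shown here, no measured step here covers a non-aromatic ring at this place, so the expectation for compound 4 rests on compound 3 sitting at the limit and on the large swing seen in an at least 1000-fold higher number from compound 2 to compound 3 (3.00 log units; beyond the scatter). The step from compound 3 to compound 4 is estimated as an at least 1.2-fold lower number from compound 3 to compound 4 (0.09 log units; that floor lies within the scatter). Compound 4 is expected to give about 8000 nM, within a range from 1500 nM to 30000 nM.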

Compound 4, inhibition constant: 5.6 nM
Compound 4: the middle estimate sits 1400-fold (3.15 log units) above what was measured; measured number outside the range, below it.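

The result shows that an aromatic ring is not needed on the carbon with a double bond to nitrogen: in this assay, cyclopentyl in place of the two substituted phenyl groups gives an at least 1700-fold lower number from compound 3 to compound 4 (3.25 log units; beyond the scatter) and an at least 1700-fold lower number from compound 1 to compound 4 (3.25 log units; beyond the scatter). Set against the aromatic quinolin-6-yl, cyclopentyl gives a 1.8-fold lower number from compound 2 to compound 4 (0.24 log units; within the scatter), so one aromatic and one non-aromatic ring are both compatible with strong binding here. Only compound 1 and compound 3, with 4-acetamidophenyl and 4-propoxyphenyl, remain at an assay limit: the limit of > 10000 nM in this assay, at which 2 of the 4 values shown sit.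

The compounds shown leave open whether the weak result belongs to the phenyl ring itself or to the acetamido and propoxy groups it carries, a question that plain phenyl would address. Also open, as far as these compounds go, is whether cyclohexyl or an open chain such as butyl would behave as cyclopentyl does.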